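A second chloro on compound 3

The source may hold more compounds than are shown below. What is called first, only, known or untested is meant among the compounds shown, and "the series" means these compounds.

In a functional assay on A375P cells (Homo sapiens) for inhibition, read by MTT assay, with a stated time of 24 h (a lower number here means a stronger inhibitor of growth, a higher number a weaker inhibitor of growth), compound 1 `COc1ccc(Cn2ncc3c2NC(=O)CC(c2ccc(NC(=O)Nc4ccc(Cl)c(C(F)(F)F)c4)cc2)=N3)cc1` gives 3930 nM, and compound 2 `COc1ccc(Cn2ncc3c2NC(=O)CC(c2cccc(NC(=O)Nc4ccc(Cl)cc4)c2)=N3)cc1` gives 640 nM. Compound 3 `O=C1CC(c2cccc(NC(=O)Nc3ccc(Cl)cc3)c2)=Nc2cn[nH]c2N1` gives > 30000 nM, which is a limit and not a number. This places compound 3 at the limit of > 30000 nM in this assay, at which 1 of the 3 values shown sits.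

Compound 4 `O=C1CC(c2cccc(NC(=O)Nc3ccc(Cl)c(Cl)c3)c2)=Nc2cn[nH]c2N1` carries chloro in place of hydrogen on an aromatic carbon, ortho to a chloro group and meta to a large group, so that 4-chlorophenyl becomes 3,4-dichlorophenyl (chloro in place of hydrogen on an aromatic carbon).

Going by the values given here, the one measured step is an at least 46-fold higher number from compound 2 to compound 3 (1.67 log units; beyond the scatter). It is large, but it concerns hydrogen in place of 4-methoxybenzyl on an aromatic nitrogen, not this change. Among the compounds with values here, no measured step covers chloro on an aromatic carbon, and compound 1 differs from compound 2 in more than one place. Compound 4 also lacks the 4-methoxybenzyl, so it is expected to remain a weak inhibitor of growth, and a result reported only as a limit is quite possible. A modest move to a lower number is expected, an at least 1.5-fold lower number from compound 3 to compound 4 (0.17 log units; that floor lies within the scatter). For compound 4 the estimate is 20000 nM, with an expected range from 6000 nM to 60000 nM.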

Compound 4, concentration for 50% growth inhibition: > 30000 nM
Compound 4 ended at the assay's limit (the forecaster's own chance of this, stated with the estimate: 55%); at least 1.5-fold (0.17 log units) between middle value and limit.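

Going by these compounds alone, compound 3 and compound 4 both end at the limit of this assay, so no step between them can be read: the limit of > 30000 nM in this assay, at which 2 of the 4 values shown sit.

The compounds shown leave open what chloro in place of hydrogen does to growth inhibition, with or without the 4-methoxybenzyl on the aromatic nitrogen.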